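Exchanging the 4-chlorophenyl group of compound 1

This account rests on a few compounds, and the source may have more. Where it says the series, first, only, none or still open, it means among the compounds named here.

Values measured so far in a functional assay on RS4-11 cells (Homo sapiens) for inhibition, read by CCK-8 assay, with a stated time of 48 h (on this read-out lower numbers stand for stronger inhibition and higher numbers for weaker inhibition), are these
- compound 1 `Nc1ccc(Oc2ccccc2-c2ccc(S(=O)(=O)NCCNC(=O)Nc3ccc(Cl)cc3)s2)cc1` gives 13600 nM
- compound 2 `Cc1ccc(-c2ccsc2S(=O)(=O)NCCNC(=O)Nc2ccc([N+](=O)[O-])cc2)c(Oc2ccc(O)c(O)c2)c1` gives 7700 nM
- compound 3 `O=C(NCCNS(=O)(=O)c1ccc(-c2ccccc2Oc2ccc([N+](=O)[O-])c([N+](=O)[O-])c2)s1)Nc1ccc(Cl)cc1` gives 6700 nM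

Compound 1 holds the highest of these three numbers, although compound 2 lies within the scatter of it. Only compound 3 is separated from it beyond the scatter, in a 2.0-fold lower number from compound 1 to compound 3 (0.31 log units; beyond the scatter), which is a modest step.

Compound 4 `Cc1cc(C)cc(NC(=O)NCCNS(=O)(=O)c2ccc(-c3ccccc3Oc3ccc(N)cc3)s2)c1` has not yet been measured. It keeps the core of compound 1 and carries 3,5-dimethylphenyl in place of 4-chlorophenyl on an amide-type nitrogen and nothing else differs.

Among the compounds with values here, no measured step touches this place. Within the data shown here, the single step available changes the group on an oxygen on an aromatic ring, so it gives only a sense of scale for this short series. Neither a direction nor a size can be drawn from it for the new exchange, and no shift beyond the scatter is expected in this assay for now.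

The expected change is a 1.1-fold lower number from compound 1 to compound 4 (0.05 log units; within the scatter) as estimated here. Compound 4 is estimated at 12000 nM, with an expected range from 5000 nM to 30000 nM.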

Compound 4, half-maximal inhibitory concentration: > 20000 nM
Compound 4 gave a limit, no number; the forecaster's own chance of this, stated with the estimate: 5%; middle value at least 1.6-fold (0.22 log units) away from the limit.
By their numbers in this assay, from the lowest: compounds 3, 2 and 1 (each within the scatter of the next, the first and the last beyond it). At a limit, above all of these: compound 4.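

In this assay compound 4 reads > 20000 nM, which is a limit of the assay and not a number. Placing 3,5-dimethylphenyl in place of 4-chlorophenyl on an amide-type nitrogen gives an at least 1.4-fold higher number from compound 1 to compound 4 (0.16 log units; that floor lies within the scatter), the first reading at this position, and it shows no gain from this exchange, though its floor alone does not establish a shift beyond the scatter. The true size of the step therefore stays unknown, and the reading marks the upper edge of what the series can resolve: the limit of > 20000 nM in this assay, at which 1 of the 4 values shown sits.

As far as these compounds go, it remains open how a plain phenyl, a methoxyphenyl or a carboxyphenyl group would read on this nitrogen. From the compounds shown here alone, it is equally open whether 3,5-dimethylphenyl would give the same result with the 3,4-dinitrophenyl group of compound 3 on the oxygen.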